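The source may hold more compounds than are shown below. What is called first, only, known or untested is meant among the compounds shown, and "the series" means these compounds.

In a functional assay on MCF7 cells (Homo sapiens) for inhibition, read by sulforhodamine B assay (on this read-out lower numbers stand for stronger inhibition and higher numbers for weaker inhibition), compound 3 (`COc1ccc(NC2=CC(=O)c3nc4n(c3C2=O)[C@H]2OC[C@@H](O)[C@H]2OC4)cc1`) gives 5420 nM, the higher of the two exact numbers in this small set. Compound 2 (`CCc1ccc(NC2=CC(=O)c3nc4n(c3C2=O)[C@H]2OC[C@@H](O)[C@H]2OC4)cc1`) gives 960 nM, and the measured step between them is a 5.6-fold higher number from compound 2 to compound 3 (0.75 log units; beyond the scatter). Compound 1 (`O=C1C=C(NC2CCCCC2)C(=O)c2c1nc1n2[C@H]2OC[C@@H](O)[C@H]2OC1`) gives > 8000 nM, which is a limit of the assay and not a number.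

Compound 4 (`O=C1C=C(N2CCCCC2)C(=O)c2c1nc1n2[C@H]2OC[C@@H](O)[C@H]2OC1`) differs from compound 3 by piperidin-1-yl in place of (4-methoxyphenyl)amino on a double-bonded ring carbon, with piperidin-1-yl in place of (4-methoxyphenyl)amino on a double-bonded ring carbon. Within the data shown here, no measured compound carries piperidin-1-yl, so the evidence is indirect. The closest measured step is an at least 1.4-fold lower number from compound 1 to compound 3 (0.16 log units; that floor lies within the scatter), which puts 4-methoxyphenyl in place of cyclohexyl on an amine nitrogen, a swap of a non-aromatic ring for an aromatic one in the reverse sense. The larger at least 8.3-fold lower number from compound 1 to compound 2 (0.92 log units; beyond the scatter) concerns 4-ethylphenyl rather than the group that leaves here.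

On that basis, no step beyond the scatter is expected in this assay, with any drift expected towards a higher number. The estimated step is a 1.4-fold higher number from compound 3 to compound 4 (0.14 log units; within the scatter). Compound 4 is expected at 7500 nM, within an estimated range of 2800 nM to 20000 nM.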

Compound 4, half-maximal inhibitory concentration: > 8000 nM
Compound 4 was reported as a limit (the forecaster's own chance of this, stated with the estimate: 45%); middle value at least 1.0-fold (0.02 log units) away from the limit.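

On this double-bonded ring carbon, piperidin-1-yl does not keep the stronger inhibition seen with (4-ethylphenyl)amino in this assay: the change gives an at least 8.3-fold higher number from compound 2 to compound 4 (0.92 log units; beyond the scatter). Against (4-methoxyphenyl)amino, the same change reads only as an at least 1.4-fold higher number from compound 3 to compound 4 (0.16 log units; that floor lies within the scatter), so no separation from that group can be claimed. The earlier compounds had shown only cyclohexylamino ending at a limit of the assay, and now a second non-aromatic ring, this one with no hydrogen-bond donor, ends at that same limit: the limit of > 8000 nM in this assay, at which 2 of the 4 values shown sit.

The step from compound 1 to compound 4 cannot be read, so these compounds do not tell whether the amine hydrogen matters when a non-aromatic ring sits on this carbon. On these data alone, it also remains open whether an aromatic ring on the amine nitrogen is itself what separates compound 2 from the two limit compounds, or whether the ethyl group is needed too, a question that a benzylamino group, a phenylamino group with no ring substituent or a 4-chlorophenylamino group would bear on.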